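A few compounds are considered here, and "the series" means these few. Any claim that something is new, unique, unknown or untested is made for them only; others in the source may bear on it.

Series notes. In an assay (Rattus norvegicus) for inhibition of Fatty-acid amide hydrolase 1 (Homo sapiens) (on this read-out higher numbers stand for weaker inhibition and lower numbers for stronger inhibition), compound 1 `Nc1ccccc1-c1cnc(C(=O)CCCCCCc2ccccc2)o1` gives 750 nM, compound 2 `N#Cc1cccc(-c2cnc(C(=O)CCCCCCc3ccccc3)o2)c1` gives 15 nM, and compound 3 `COC(=O)c1ccc(-c2cnc(C(=O)CCCCCCc3ccccc3)o2)cc1` gives 40 nM. On these three numbers compound 3 stands second highest, closer to compound 2 than to compound 1. Compound 4 `O=C(O)c1ccc(-c2cnc(C(=O)CCCCCCc3ccccc3)o2)cc1` is not yet measured; it differs from compound 3 by hydrogen in place of methyl on an oxygen next to a carbonyl group. Going by the values given here, the only measured step, a 50-fold lower number from compound 1 to compound 2 (1.70 log units; beyond the scatter), changes the aryl substituent and leaves the ester untouched, so no measured step bears directly on this change; the expectation must stay wide. The numbers seen so far run from compound 1 down to compound 2, and the estimate is placed within that span. For compound 4 the estimate in this assay is 150 nM, with a range of 30 nM to 800 nM. The expected step is a 3.8-fold higher number from compound 3 to compound 4 (0.57 log units; beyond the scatter).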

Compound 4, inhibition constant: 60 nM
The estimate for compound 4 lay 2.5-fold (0.40 log units) above the measured number, within the range that was stated.
By their numbers in this assay, from the lowest: compound 2; then compounds 3 and 4 (each within the scatter of the next); then compound 1.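

In this assay, hydrogen in place of methyl on an oxygen next to a carbonyl group gives a 1.5-fold higher number from compound 3 to compound 4 (0.18 log units; within the scatter), so methoxycarbonyl and carboxy are not told apart on this aryl group. The carboxy compound keeps most of the gain over the amine: a 13-fold lower number from compound 1 to compound 4 (1.10 log units; beyond the scatter). It does not match the nitrile, with a 4.0-fold higher number from compound 2 to compound 4 (0.60 log units; beyond the scatter). Nothing measured here gives a reason for these steps.
As far as these compounds go, whether a primary amide or a hydroxymethyl group in the same place would also leave the number unchanged remains open, as does whether a carboxylic acid on the 3-substituted phenyl would match the nitrile.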